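Lengthening the Chain on a Shared Sulfonamide Core

The compounds below may be only part of what the source reports. "The series", "measured", "known", "first", "only" and "open" are said of these compounds alone.

Compound 1, `CCCCCc1ccc(NS(=O)(=O)c2ccc(N3CCNC3=O)cc2)cc1`, gives 990 nM in a functional assay on HT-29 cells (Homo sapiens) for antiproliferative activity, read by sulforhodamine B assay, with a stated time of 48 h; a lower number here means a stronger inhibitor, a higher number a weaker inhibitor.
Compound 2, `O=C1NCCN1c1ccc(S(=O)(=O)Nc2ccccc2)cc1`, gives 280 nM.
Compound 3, `Cc1ccc(NS(=O)(=O)c2ccc(N3CCNC3=O)cc2)cc1`, gives 480 nM.

Compound 3 stands second highest of the three numbers. Its closest value is that of compound 2, a 1.7-fold higher number from compound 2 to compound 3 (0.23 log units; within the scatter), a gap within the scatter, while compound 1 lies further off, a 2.1-fold lower number from compound 1 to compound 3 (0.31 log units; beyond the scatter), beyond it. Compound 4, `CCCCCCCc1ccc(NS(=O)(=O)c2ccc(N3CCNC3=O)cc2)cc1`, differs from compound 3 by hexyl in place of hydrogen on a saturated chain carbon bound to an aromatic carbon. Within the data shown here, two measured steps bear on this change, both running in the opposite direction along the same chain. Shortening the chain gave a 2.1-fold lower number from compound 1 to compound 3 (0.31 log units; beyond the scatter); removing it entirely gave a 3.5-fold lower number from compound 1 to compound 2 (0.55 log units; beyond the scatter). Among the measured compounds shown here, both modest steps point the same way: a longer chain on this carbon goes with a higher number, and no measured compound goes against that. Compound 4 carries a chain longer than that of compound 1, so a higher number than compound 3 is expected, a 3.1-fold higher number from compound 3 to compound 4 (0.49 log units; beyond the scatter). Compound 4 is therefore estimated at 1500 nM, with a range from 600 nM to 4000 nM.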

Compound 4, half-maximal inhibitory concentration: > 1000 nM
Compound 4: a limit, no number (the forecaster's own chance of this, stated with the estimate: 5%); the middle value is on the limit's open side.
By their numbers in this assay, from the lowest: compounds 2 and 3 (each within the scatter of the next); then compound 1. At a limit, above all of these: compound 4.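

For compound 4, the reading in this assay is a limit of the assay, not a number: the limit of > 1000 nM in this assay, at which 1 of the 4 values shown sits. Even so, the limit gives two readable steps, an at least 2.0-fold higher number from compound 3 to compound 4 (0.31 log units; beyond the scatter) and an at least 3.5-fold higher number from compound 2 to compound 4 (0.55 log units; beyond the scatter), so the heptyl chain on compound 4 keeps to the pattern of longer chains going with higher numbers, and none of the compounds shown goes against it. The third step, a number no lower from compound 1 to compound 4 (the limit leaves the size open), cannot be read, so whether heptyl gives a higher number than pentyl remains unsettled.

The compounds shown leave open how an ethyl or propyl chain would read at this position, which would show how the number changes with shorter chains. They also leave open whether an amine or a carboxylic acid at the end of a long chain would change the number.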